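Acid to methylamide at the chain end of compound 2

The source may report more compounds than this note shows. Statements on the series, on what has been measured and on what is new or still open speak of the compounds shown alone.

Measured compounds in a functional assay on CHO cells for agonist activity at Free fatty acid receptor 1 (Homo sapiens), read by a luciferase reporter; a lower number here means a smaller maximal response, a higher number a larger maximal response:
compound 1, `Cc1nc(-c2ccc(C(F)(F)F)cc2)sc1CNc1ccc(CCC(=O)O)cc1`, 108%
compound 2, `O=C(O)CCCc1ccc(NCc2cccc(Oc3ccccc3)c2)cc1`, 59%
compound 3, `Cc1nc(-c2ccc(C(F)(F)F)cc2)sc1CNc1ccc(CC(C)C(=O)O)cc1`, 100%

Compound 2 gives the lowest maximal response of the three, and its gap to compound 3 and to compound 1 lies beyond the usual scatter. Within the data shown here, compound 1 and compound 3 share a core that compound 2 does not have; the only one-place step measured so far, a number 8 percentage points lower from compound 1 to compound 3 (within the scatter), sits on that core and changes the chain carbon, not the acid.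

Compound 4, `CNC(=O)CCc1ccc(NCc2cccc(Oc3ccccc3)c2)cc1`, is compound 2 with methylcarbamoyl in place of carboxymethyl on a saturated chain carbon, two bonds along the chain from an aromatic carbon. Among the measured compounds shown here, no measured step touches this change: every compound measured so far carries the carboxylic acid, so the data give no direct guide to what replacing it does. The step from compound 1 to compound 3 concerns another position and is within scatter, so it does not help here. With nothing to anchor it, the expectation for compound 4 is set below compound 2, with a wide range, as a number 29 percentage points lower from compound 2 to compound 4 (beyond the scatter). Compound 4 is therefore estimated at 30%, between 5% and 60%.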

Compound 4, largest response reached (reported as percent of maximum), in percent of the reference or control that the assay uses: 67%
Beside the measured number, compound 4's estimate is 37 percentage points below it; measured number above the stated range.
By their numbers in this assay, from the lowest: compounds 2 and 4 (each within the scatter of the next); then compounds 3 and 1 (each within the scatter of the next).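

The exchange reads as a number 8 percentage points higher from compound 2 to compound 4 (within the scatter) in this assay and so leaves the maximal response at this position without a distinguishable shift. Compound 4 is the only compound shown without a carboxylic acid, so in this pair the acid at the chain end is not required for the response seen with compound 2. Nothing available gives a reason for this result.

Whether the methylamide would behave the same way on the shared core of compound 1 and compound 3 remains open, as that core is shown only with the carboxylic acid. Also open, from the compounds shown here alone, is how other chain ends on compound 2 would compare in this assay such as an unsubstituted carboxamide, a tetrazole or a dimethylamide.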